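Bromo for methyl on the pyridine-bearing side chain series

The compounds below may be only part of what the source reports. "The series", "measured", "known", "first", "only" and "open" are said of these compounds alone.

Of the compounds shown here, three of the shared core have been measured in an assay on K177 cells for activation of Neuronal acetylcholine receptor; alpha4/beta2 (Homo sapiens); on this read-out lower numbers stand for an effect already at smaller amounts and higher numbers for an effect only at larger amounts of compound. Compound 1 `Cc1cncc(OC[C@@H]2CCCN2C)c1` gives 2300 nM; compound 2 `CCc1cncc(OC[C@@H]2CCCN2C)c1` gives 1000 nM; compound 3 `Cc1ccc(OC[C@@H]2CCCN2C)cn1` gives 2200 nM. Within the data shown here, the only single-point step measured so far is a 2.3-fold lower number from compound 1 to compound 2 (0.36 log units; beyond the scatter). Compound 3 stands second highest of the three numbers; its value and that of compound 1 lie within the scatter of each other, while compound 2 sits beyond the scatter below it.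

Compound 4 `CN1CCC[C@H]1COc1ccc(Br)nc1` differs from compound 3 by bromo in place of methyl on an aromatic carbon. Among the measured compounds shown here, no measured step concerns this change: the one step on record alters a saturated chain carbon, not a substituent on the aromatic ring, so it gives no direction for this assay. With nothing to lean on, the expected step is a 1.5-fold lower number from compound 3 to compound 4 (0.17 log units; within the scatter), that is none beyond the scatter, with a wide range to reflect the lack of precedent. Compound 4 is therefore estimated at 1500 nM, with a range from 250 nM to 6000 nM.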

Compound 4, half-maximal effective concentration: 2600 nM
Estimate against measurement, compound 4: 1.7-fold (0.24 log units) below; the range from low to high includes it.
By their numbers in this assay, from the lowest: compound 2; then compounds 3, 1 and 4 (each within the scatter of the next).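

In this assay, among these compounds, bromo in place of methyl on the aromatic carbon next to the ring nitrogen gives (a 1.2-fold higher number from compound 3 to compound 4 (0.07 log units; within the scatter)), the first reading of a change made directly on a ring carbon. Among the compounds shown here, at this place, the two groups cannot be told apart on this read-out, whereas the only earlier step, (a 2.3-fold lower number from compound 1 to compound 2 (0.36 log units; beyond the scatter)), concerned a saturated chain carbon and lay beyond the scatter. No measurement on hand offers an explanation for this result.

On these data alone, it remains open whether a group of another kind on this carbon, such as an amine, a methoxy group or a carboxylic acid, would move the number beyond the scatter. Also open, as far as these compounds go, are the effect of a longer chain such as ethyl here and whether bromo would match methyl at the ring place it occupies in compound 1.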